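The source may report more compounds than this note shows. Statements on the series, on what has been measured and on what is new or still open speak of the compounds shown alone.

The three measured compounds, each with a value that is a limit of the assay rather than a number:
compound 1, `Nc1nc(OCC(F)(F)F)c2ncn(/C=C3/CC3(CO)CO)c2n1`, > 20000 nM
compound 2, `C=CCOc1nc(N)nc2c1ncn2/C=C1/CC1(CO)CO`, > 20000 nM
compound 3, `CC(C)Nc1nc(N)nc2c1ncn2/C=C1/CC1(CO)CO`, > 20000 nM

In an ADME assay on CCRF-HSB-2 cells (Homo sapiens) for cytotoxicity, with a stated time of 7 days (on this read-out lower numbers stand for higher toxicity in this test and higher numbers for lower toxicity in this test), compound 2 stands at the limit of the assay, and no number is known for it. The two further values shown are likewise limits. Compound 4, `Nc1nc(NC2CCCCC2)c2ncn(/C=C3/CC3(CO)CO)c2n1`, differs from compound 2 in one place: cyclohexylamino in place of allyloxy on an aromatic carbon. The measured steps that touch compound 2 are a step that the two limits leave unreadable from compound 1 to compound 2 and a step that the two limits leave unreadable from compound 2 to compound 3, and a third, a step that the two limits leave unreadable from compound 1 to compound 3, is of the same kind. None of them has a readable size because of the limit of > 20000 nM in this assay, at which 3 of the 3 values shown sit. Among the compounds with values here, the changes made so far on this aromatic carbon, from 2,2,2-trifluoroethoxy through allyloxy to isopropylamino, have all left the read-out at the limit, and no measured step points in any direction. No direction and no size beyond the scatter is therefore expected for a number no higher from compound 2 to compound 4 (the limit leaves the size open). Compound 4 is expected to give 20000 nM, estimated within 8000 nM to 20000 nM, most likely again reported as a limit rather than a number.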

Compound 4, half-maximal cytotoxic concentration: > 20000 nM
Compound 4: only a limit was reported (the forecaster's own chance of this, stated with the estimate: 85%); the middle value lies on the limit itself.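

Within the data shown here, no step from compound 1, compound 2 or compound 3 to compound 4 can be read in this assay, because all four give a limit rather than a number: the limit of > 20000 nM in this assay, at which 4 of the 4 values shown sit. The compounds shown leave open whether these groups on the aromatic carbon differ at all in toxicity in this test.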